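A few compounds are considered here, and "the series" means these few. Any claim that something is new, unique, unknown or untested is made for them only; others in the source may bear on it.

Compound 1, `CC(=O)Nc1cccc2c1CCCC2c1c[nH]cn1`: 4.84
Compound 2, `CS(=O)(=O)Nc1cccc2c1OCCC2c1c[nH]cn1`: 5.09
Compound 3, `COc1ccc(NS(C)(=O)=O)c2c1C(c1c[nH]cn1)CCC2`: 4.74

Of the compounds shown here, three have been tested in a functional assay on spleen for agonist activity at Alpha-1B adrenergic receptor (Rattus norvegicus); a higher number here means a more potent compound, by a factor of ten per unit of this negative logarithm, a lower number a less potent compound. Compound 1 gives 4.84. Its number falls between those of the other two, with compound 3 at 4.74 the nearer of them and compound 2 at 5.09 the further, but both gaps lie within the scatter of repeated measurements, so no ranking of the three can be drawn from these numbers; they are, as far as the data show, indistinguishable.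

The next compound, compound 4, `O=C(Nc1cccc2c1CCCC2c1c[nH]cn1)C(F)(F)F`, is built from compound 1 by a single change: trifluoromethyl in place of methyl on a carbonyl carbon. Within the data shown here, no measured pair among the three shows this change, so its effect cannot be read from a measured step. What can be said is that the three measured compounds, which differ from one another in several places at once, all give numbers within the scatter of one another, and nothing in the data points toward a large movement in either direction.

The step expected from this change, a number 0.04 log units lower from compound 1 to compound 4 (within the scatter), is therefore taken to be small, not beyond the scatter, with no direction favoured. For compound 4 the estimated value in this assay is 4.8, with a range from 4.2 to 5.4.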

Compound 4, negative logarithm of the half-maximal effective concentration: 5.47
Beside the measured number, compound 4's estimate is 0.67 log units below it, and the stated range ends below it.
By their numbers in this assay, from the lowest: compounds 3, 1 and 2 (each within the scatter of the next, the first and the last beyond it); then compound 4.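

The earlier compounds shown here differed from one another in several places at once, so they offered no step that could be read for a single change. In this assay, the pair of compound 1 and compound 4 now supplies one: trifluoromethyl in place of methyl on a carbonyl carbon gives a number 0.63 log units higher from compound 1 to compound 4 (beyond the scatter), a modest step but one beyond the scatter, which shows that the number responds to what is carried on this carbonyl carbon. No measurement shown here bears on why the number rises with this change.

On these data alone, this finding rests on a single pair, so it remains open whether the rise is particular to trifluoromethyl or would also appear with other groups on the same carbonyl carbon, such as ethyl, a longer chain or an amine. Also open, as far as these compounds go, is whether fluoromethyl or difluoromethyl in that place would give part of the step, or none of it.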